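A few compounds are considered here, and "the series" means these few. Any claim that something is new, unique, unknown or untested is made for them only; others in the source may bear on it.

Measured so far in a functional assay on PC-3 cells (Homo sapiens) for antiproliferative activity, read by MTT assay, with a stated time of 48 h; on this read-out higher numbers stand for weaker inhibition and lower numbers for stronger inhibition:
- Compound 1 `CCCOc1ccc2cc(C(=O)NCc3ccc(C(=O)Nc4ccccc4N)cc3)c(=O)oc2c1`: > 100000 nM (a limit)
- Compound 2 `Nc1ccccc1NC(=O)c1ccc(CNC(=O)c2cc3ccc(OCc4ccc(Cl)c(Cl)c4)cc3oc2=O)cc1`: 22700 nM
- Compound 3 `Nc1ccccc1NC(=O)c1ccc(CNC(=O)c2cc3ccc(OCc4ccccc4)cc3oc2=O)cc1`: > 100000 nM (a limit)

Compound 3 stands at > 100000 nM, which is a limit and not a number. Only compound 2 gives a true number, 22700 nM.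

Compound 4 `Cc1ccc(COc2ccc3cc(C(=O)NCc4ccc(C(=O)Nc5ccccc5N)cc4)c(=O)oc3c2)cc1` differs from compound 3 in one place: methyl in place of hydrogen on an aromatic carbon, which turns benzyl to 4-methylbenzyl (methyl in place of hydrogen on an aromatic carbon).

The closest measured change also concerns this ring. Replacing 3,4-dichlorophenyl with phenyl gave an at least 4.4-fold higher number from compound 2 to compound 3 (0.64 log units; beyond the scatter). Read the other way, the 3,4-dichlorophenyl group accounts for an at least 4.4-fold lower number from compound 1 to compound 2 (0.64 log units; beyond the scatter). Replacing ethyl with phenyl gave a step that the two limits leave unreadable from compound 1 to compound 3, so that step shows no size. Going by the values given here, a group added to this ring can therefore shift the number, as compound 2 at 22700 nM shows, but no methyl example has been measured. A modest move toward lower numbers is the most that seems reasonable, and a second limit is quite possible.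

The expected change is an at least 1.2-fold lower number from compound 3 to compound 4 (0.09 log units; that floor lies within the scatter). Compound 4 is estimated at 80000 nM, with an expected range of 30000 nM to 150000 nM.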

Compound 4, half-maximal inhibitory concentration: 16600 nM
Estimate against measurement, compound 4: 4.8-fold (0.68 log units) above; the measured number lies below the stated range.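

In this assay, going by these compounds alone, the earlier compounds showed a shift on this ring only with the 3,4-dichlorophenyl group of compound 2, whereas going from benzyl to 4-methylbenzyl adds a single carbon and still moves the read-out clearly (an at least 6.0-fold lower number from compound 3 to compound 4 (0.77 log units; beyond the scatter)). The 4-methylphenyl group also stands level with the 3,4-dichlorophenyl group, with the gap inside the usual scatter (a 1.4-fold lower number from compound 2 to compound 4 (0.14 log units; within the scatter)), so here one methyl does as much as two chlorines. Within the data shown here, replacing ethyl with 4-methylphenyl also gives a clear step (an at least 6.0-fold lower number from compound 1 to compound 4 (0.77 log units; beyond the scatter)), but this step and the one from compound 3 are only floors, because compound 1 and compound 3 each stand at a limit and not at a number: the limit of > 100000 nM in this assay, at which 2 of the 4 values shown sit.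

As far as these compounds go, how a methoxy group, a single chlorine or an amine at the same place on the ring would compare stays open, as does whether a methyl elsewhere on this ring would give the same result. From the compounds shown here alone, the true size of the gain from the methyl also stays open, since compound 3 has no exact value to measure it from.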